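Thiocarbamoyl to dimethylphenylcarbamoyl on the shared core

A few compounds are considered here, and "the series" means these few. Any claim that something is new, unique, unknown or untested is made for them only; others in the source may bear on it.

Values in a functional assay on RS4-11 cells (Homo sapiens) for inhibition, read by CCK-8 assay, with a stated time of 48 h; on this read-out lower numbers stand for stronger inhibition and higher numbers for weaker inhibition:
- Compound 1 `O=S(=O)(NCCNC(=S)Nc1cccc(Cl)c1)c1ccc(-c2ccccc2OCc2cccc(O)c2)s1`: 5800 nM
- Compound 2 `Cc1cc(C)cc(NC(=O)NCCNS(=O)(=O)c2ccc(-c3ccccc3OCc3ccccc3)s2)c1`: > 50000 nM (a limit)
- Compound 3 `O=[N+]([O-])c1ccc(NC(=S)NCCNS(=O)(=O)c2ccc(-c3ccccc3OCc3cccc(O)c3)s2)cc1`: 10100 nM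

For the measured compounds named here, only two numeric readings exist in this assay, and the gap between them is a 1.7-fold higher number from compound 1 to compound 3 (0.24 log units; within the scatter). Going by the values given here, compound 3 thus stands level with compound 1, its only numeric neighbour.

Compound 4 `Cc1cc(C)cc(NC(=O)NCCNS(=O)(=O)c2ccc(-c3ccccc3OCc3cccc(O)c3)s2)c1` keeps the core of compound 3 and exchanges the group on the amine nitrogen: a group of 11 heavy atoms (9 carbon, 1 nitrogen, 1 oxygen; one six-membered aromatic ring of carbon only) in place of a group of 12 heavy atoms (7 carbon, 2 nitrogen, 2 oxygen, 1 sulfur; one six-membered aromatic ring of carbon only), on an amine nitrogen. Among the compounds with values here, the one measured step, a 1.7-fold higher number from compound 1 to compound 3 (0.24 log units; within the scatter), exchanges only the aryl group, so it offers little guidance on replacing the whole group. Compound 4 shares the (3,5-dimethylphenyl)carbamoyl group with compound 2 but has a hydroxyl group that compound 2 lacks. Compound 2 gives > 50000 nM, which is a limit and not a number, so a higher number than for compound 3 is expected in this assay. The hydroxyl group separates the two. The expectation stays moderate, and a limit reading remains possible. The expected step is a 2.2-fold higher number from compound 3 to compound 4 (0.34 log units; beyond the scatter). For compound 4 the estimated value is 22000 nM, with an expected range of 8000 nM to 50000 nM.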

Compound 4, half-maximal inhibitory concentration: 5800 nM
For compound 4 the middle estimate is 3.8-fold (0.58 log units) above the measured one; the whole stated range lies above it.
By their numbers in this assay, from the lowest: compounds 1, 4 and 3 (each within the scatter of the next). At a limit, above all of these: compound 2.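

On the amine nitrogen, the (3,5-dimethylphenyl)carbamoyl group reads level with both earlier groups in this assay: a 1.7-fold lower number from compound 3 to compound 4 (0.24 log units; within the scatter) and no change at the digits printed from compound 1 to compound 4 (within the scatter). For the compounds shown here, with that group held fixed, hydroxy in place of hydrogen on an aromatic carbon gives an at least 8.6-fold lower number from compound 2 to compound 4 (0.93 log units; beyond the scatter), the only step here beyond the scatter, and this separates the hydroxyl change from the exchange on the amine nitrogen, which stays within the scatter in both readable comparisons. Compound 2 stands at a limit and not at a number, and the size of its step is therefore only a lower bound: the limit of > 50000 nM in this assay, at which 1 of the 4 values shown sits.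

The hydroxyl step rests on a single pair, carrying the (3,5-dimethylphenyl)carbamoyl group, and the compounds shown do not tell whether it holds with the 3-chlorophenyl or 4-nitrophenyl groups of compound 1 and compound 3. Also open, going by these compounds, is whether a methoxy group, an amine or a carboxylic acid in place of the hydroxyl would keep the reading of compound 4, and what a longer chain in place of the saturated chain would do.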